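The compounds below may be only part of what the source reports. "The series", "measured", "known", "first", "only" and "open" are said of these compounds alone.

Series notes. Three compounds sharing the core of compound 1 `Clc1ccc(Cc2nn3cc(-c4ccc(Br)cc4)nc3s2)cc1` have been run in an ADME assay on CCRF-CEM cells (Homo sapiens) for cytotoxicity, with a stated time of 72 h; a higher number here means a weaker inhibitor, a lower number a stronger inhibitor. In this assay compound 1 gives > 250000 nM, which is a limit of the assay and not a number. Compound 2 `COc1ccc(-c2cn3nc(Cl)sc3n2)cc1` is the second member. In this assay compound 2 gives > 250000 nM, again a limit rather than a number. Compound 3 `Cc1ccc(-c2cn3nc(Cc4ccc(Cl)cc4)sc3n2)cc1` is the methyl analogue. In this assay compound 3 gives > 250000 nM, also a limit. Compound 3 therefore stands at the edge of what this assay reports, and the step that the two limits leave unreadable from compound 1 to compound 3 cannot be read because both ends sit at the limit of > 250000 nM in this assay, at which 3 of the 3 values shown sit.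

Compound 4 `Clc1ccc(Cc2nn3cc(-c4ccccc4)nc3s2)cc1` follows from compound 3 by hydrogen in place of methyl on an aromatic carbon, that is 4-methylphenyl to phenyl. Going by the values given here, the only measured step with any bearing on it is a step that the two limits leave unreadable from compound 1 to compound 3, which exchanges one group at the same aromatic carbon and yields no readable size. None of the three values shows a compound that becomes an inhibitor within the measured range. The expected step that the limit leaves unreadable from compound 3 to compound 4 is accordingly none beyond the scatter, with a limit again the most probable outcome. Compound 4 is estimated at 300000 nM, within 100000 nM to 1000000 nM, in this assay.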

Compound 4, half-maximal inhibitory concentration: > 250000 nM
Compound 4 ended at the assay's limit (the forecaster's own chance of this, stated with the estimate: 85%); the middle value is on the limit's open side.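

In this assay compound 4 gives > 250000 nM, again a limit and not a number. No step among compound 1, compound 3 and compound 4 can be read, because all of them sit at the same edge: the limit of > 250000 nM in this assay, at which 4 of the 4 values shown sit.

The compounds shown leave open how the bromo, methyl and hydrogen analogues rank against one another in this assay.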